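This account rests on a few compounds, and the source may have more. Where it says the series, first, only, none or still open, it means among the compounds named here.

Working notes on the series. The shared core carries two propyl chains, and variation sits on the aromatic substituent attached to it. Compound 1 `CCCn1c(=O)c2nc(-c3cnn(Cc4cc(C(F)(F)F)ccc4Cl)c3)[nH]c2n(CCC)c1=O` gives 22 nM in an in vitro assay on HEK293 cells for displacement of a labelled ligand from adenosine receptor A2b (Homo sapiens) (on this read-out higher numbers stand for weaker inhibition and lower numbers for stronger inhibition), the lowest of the three measured values. Compound 3 `CCCn1c(=O)c2nc(-c3cnn(Cc4cc(C(F)(F)F)cc(Cl)c4F)c3)[nH]c2n(CCC)c1=O` gives 360 nM in this assay, and compound 2 `CCCn1c(=O)c2nc(-c3ccnn3-c3ccccc3)[nH]c2n(CCC)c1=O`, with a different link between the core and its aromatic part, gives 1100 nM; both numbers stand well above that of compound 1, beyond the usual scatter.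

Compound 4 `CCCn1c(=O)c2nc(-c3cnn(Cc4ccc(F)cc4F)c3)[nH]c2n(CCC)c1=O` has not yet been measured. Relative to compound 1 it differs in one place: 2,4-difluorophenyl in place of 2-chloro-5-(trifluoromethyl)phenyl on a saturated chain carbon bound to an aromatic nitrogen. Both the chlorine and the trifluoromethyl group of compound 1 leave, and a smaller ring with two fluorines enters on the same chain carbon.

Compound 1 shows that its substituted benzyl group is compatible with a low number in this assay, whereas compound 3 with a different substitution pattern gives 360 nM. The change to compound 4 is expected to move the value upward by a step beyond the scatter, a 6.8-fold higher number from compound 1 to compound 4 (0.83 log units; beyond the scatter). Compound 4 is estimated at 150 nM, within a range from 40 nM to 600 nM.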

Compound 4, inhibition constant: 700 nM
Estimate against measurement, compound 4: 4.7-fold (0.67 log units) below; measured number above the stated range.
By their numbers in this assay, from the lowest: compound 1; then compounds 3, 4 and 2 (each within the scatter of the next, the first and the last beyond it).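

The series now has its first change in one place only: in this assay, 2,4-difluorophenyl in place of 2-chloro-5-(trifluoromethyl)phenyl on a saturated chain carbon bound to an aromatic nitrogen gives a 32-fold higher number from compound 1 to compound 4 (1.50 log units; beyond the scatter). The low number of compound 1 is therefore not carried by the shared core and the chain carbon alone, and it depends strongly on the aromatic group held at this position. Nothing available explains the size of this step.

The chlorine and the trifluoromethyl group leave together and two fluorines enter, so the part each plays in the step stays unresolved. Also open, on these data alone, is whether a methoxy group or a nitrile on that ring, in place of the chlorine or the trifluoromethyl group, would keep a low number in this assay.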